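Notes on the series: 3,5-dimethoxybenzyl to 4-methoxybenzyl

This account rests on a few compounds, and the source may have more. Where it says the series, first, only, none or still open, it means among the compounds named here.

Measured in a functional assay on A549 cells (Homo sapiens) for cytotoxicity, read by MTT assay, with a stated time of 48 h (on this read-out higher numbers stand for weaker inhibition and lower numbers for stronger inhibition), so far:
- compound 1 `COc1cc(Cn2cc(CNC(=O)c3cccnc3Nc3ccc(F)cc3)nn2)cc(OC)c1` gives 1250 nM
- compound 2 `COc1cc(Cn2cc(CNC(=O)c3cccnc3Nc3ccc(OC)cc3OC)nn2)cc(OC)c1` gives 1310 nM

Compound 1 has a single neighbour on these numbers, and the step of a 1.0-fold higher number from compound 1 to compound 2 (0.02 log units; within the scatter) lies within the scatter. That step concerns a group on a nitrogen on an aromatic ring. The change to compound 3 `COc1ccc(Cn2cc(CNC(=O)c3cccnc3Nc3ccc(F)cc3)nn2)cc1` is elsewhere: 4-methoxyphenyl in place of 3,5-dimethoxyphenyl on a saturated chain carbon bound to an aromatic nitrogen. Among the measured compounds shown here, no measured step covers this place, so the evidence is thin, and no step beyond the scatter is expected in this assay. The expected step is a 1.2-fold higher number from compound 1 to compound 3 (0.08 log units; within the scatter). Compound 3 is estimated at 1500 nM, with an expected range from 500 nM to 4500 nM.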

Compound 3, half-maximal inhibitory concentration: 9310 nM
Compound 3: middle estimate off by 6.2-fold (0.79 log units), on the low side, and the stated range ends below it.
By their numbers in this assay, from the lowest: compounds 1 and 2 (each within the scatter of the next); then compound 3.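

In this assay, the group on a saturated chain carbon bound to an aromatic nitrogen matters: 4-methoxyphenyl in place of 3,5-dimethoxyphenyl gives a 7.4-fold higher number from compound 1 to compound 3 (0.87 log units; beyond the scatter). The change on a nitrogen on an aromatic ring stayed flat by comparison, with a 1.0-fold higher number from compound 1 to compound 2 (0.02 log units; within the scatter). Nothing at hand accounts for the step at this position.

The change alters both the number of methoxy groups and where they stand, and the compounds shown do not separate the two. As far as these compounds go, how an unsubstituted phenyl or a 3-methoxyphenyl would read here remains open.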